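Working notes: the step from compound 3 to compound 4

The source may hold more compounds than are shown below. What is called first, only, known or untested is meant among the compounds shown, and "the series" means these compounds.

In a functional assay on MCF7 cells (Homo sapiens) for antiproliferative activity, read by MTT assay, with a stated time of 72 h (on this read-out lower numbers stand for stronger inhibition and higher numbers for weaker inhibition), three compounds sharing one core have been measured. Compound 1 `CC(C)(C)c1cn(C[C@H](O)[C@H]2OC(=O)C(OCc3ccccc3)=C2OCc2ccccc2)nn1` gives 730 nM, compound 2 `O=C1O[C@H]([C@@H](O)Cn2cc(C3CC3)nn2)C(OCc2ccccc2)=C1OCc1ccccc1` gives 25900 nM and compound 3 `O=C1O[C@H]([C@@H](O)Cn2cc(CNS(=O)(=O)c3ccc(Cl)cc3)nn2)C(OCc2ccccc2)=C1OCc1ccccc1` gives 4170 nM. Compound 3 therefore holds the second highest of the three numbers, with a 5.7-fold higher number from compound 1 to compound 3 (0.76 log units; beyond the scatter) on one side and a 6.2-fold lower number from compound 2 to compound 3 (0.79 log units; beyond the scatter) on the other.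

Compound 4 `O=C1O[C@H]([C@@H](O)Cn2cc(CCCCl)nn2)C(OCc2ccccc2)=C1OCc1ccccc1` carries 2-chloroethyl in place of ((4-chlorophenyl)sulfonyl)amino on a saturated chain carbon bound to an aromatic carbon. Cut one bond further out, this reads 3-chloropropyl in place of (((4-chlorophenyl)sulfonyl)amino)methyl.

Among the compounds with values here, no measured step covers this exchange directly, and no measured compound carries a chlorinated chain. The nearest evidence is the three steps at the same place on the core. The widest of them, a 35-fold higher number from compound 1 to compound 2 (1.55 log units; beyond the scatter), shows that a change between two groups without a sulfonyl amino unit can be large, so the direction is poorly constrained. With compound 3 lying inside the measured span, a step of no more than modest size is expected, leaning slightly towards a higher number. The estimated change is a 1.4-fold higher number from compound 3 to compound 4 (0.16 log units; within the scatter). For compound 4 the expected value is 6000 nM, with an estimated range of 1500 nM to 24000 nM.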

Compound 4, half-maximal inhibitory concentration: 24500 nM
Compound 4: the middle estimate sits 4.1-fold (0.61 log units) below what was measured; the measured number lies above the stated range.
By their numbers in this assay, from the lowest: compound 1; then compound 3; then compounds 4 and 2 (each within the scatter of the next).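

In this assay, the exchange of (((4-chlorophenyl)sulfonyl)amino)methyl for 3-chloropropyl at this position is not neutral, giving a 5.9-fold higher number from compound 3 to compound 4 (0.77 log units; beyond the scatter); the sulfonyl-bearing group therefore now stands apart from two groups rather than one. The flexible chlorinated chain and the small cyclopropyl ring cannot be told apart, with a 1.1-fold lower number from compound 2 to compound 4 (0.02 log units; within the scatter), while tert-butyl keeps a wide lead over the chain, with a 34-fold higher number from compound 1 to compound 4 (1.53 log units; beyond the scatter), leaving compound 1 the strongest of the four and showing that an open chain at this place does not by itself reproduce what tert-butyl gives. The data shown offer no independent measurement that accounts for any of these steps.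

Going by these compounds, whether the chlorine contributes to the value of compound 4 stays open, and a plain propyl chain or a 3-hydroxypropyl chain at the same place would address that. On these data alone, it is also open which part of the (((4-chlorophenyl)sulfonyl)amino)methyl group separates compound 3 from compound 4, and an aminomethyl group or the same group without its chlorine would help divide the sulfonyl amino unit from the aromatic ring.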